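From carbamoyl to amino: what to expect for compound 4

This account rests on a few compounds, and the source may have more. Where it says the series, first, only, none or still open, it means among the compounds named here.

Measured so far in a functional assay (aorta) with Oryctolagus cuniculus as the target; on this read-out higher numbers stand for weaker binding and lower numbers for tighter binding:
- compound 1 `COc1cc(C(C)=O)ccc1OCCCN1CCC(C(c2ccc(F)cc2)c2ccc(F)cc2)CC1` gives 1.59 nM
- compound 2 `COc1cc(C(C)=O)ccc1OCCCN1CCC(C(c2ccc(F)cc2)c2ccccn2)CC1` gives 158 nM
- compound 3 `COc1cc(C(C)=O)ccc1OCCCN1CCC(C(C(N)=O)(c2ccc(F)cc2)c2ccc(F)cc2)CC1` gives 25.1 nM

Among these three numbers, compound 3 stands in the middle, with compound 1 lower and compound 2 higher. The next molecule, compound 4 `COc1cc(C(C)=O)ccc1OCCCN1CCC(C(N)(c2ccc(F)cc2)c2ccc(F)cc2)CC1`, has amino in place of carbamoyl on a saturated chain carbon bound to two aromatic carbons and a saturated ring carbon, a swap counted as amino in place of carbamoyl on a saturated chain carbon bound to two aromatic carbons and a saturated ring carbon here.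

Among the compounds with values here, two measured steps bear on this. The closest is a 16-fold higher number from compound 1 to compound 3 (1.20 log units; beyond the scatter), where carbamoyl took the place of hydrogen on that same carbon, and the number rose by a large margin. The other is a 99-fold higher number from compound 1 to compound 2 (2.00 log units; beyond the scatter), also large, which shows that a change in the groups on this carbon can matter greatly. Within the data shown here, no measured compound carries amino at this place, so the size of the step remains uncertain. The expected result is a 2.5-fold lower number from compound 3 to compound 4 (0.40 log units; beyond the scatter) in this assay, a moderately lower number. Compound 4 is estimated at 10 nM, with an expected range from 2 nM to 50 nM.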

Compound 4, dissociation constant: 31.6 nM
Beside the measured number, compound 4's estimate is 3.2-fold (0.50 log units) below it; low and high end bracket the measured number.
By their numbers in this assay, from the lowest: compound 1; then compounds 3 and 4 (each within the scatter of the next); then compound 2.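

In this assay, amino in place of carbamoyl on this carbon gives a 1.3-fold higher number from compound 3 to compound 4 (0.10 log units; within the scatter), so the two groups cannot be told apart here, even though carbamoyl has 3 heavy atoms and amino has 1. Amino in place of hydrogen gives a 20-fold higher number from compound 1 to compound 4 (1.30 log units; beyond the scatter), so a large step away from compound 1 now appears with two different groups at this position, not just with carbamoyl. No evidence is available to explain this result.

The compounds shown leave open whether other groups on this carbon, such as a hydroxyl, a methyl or a dimethylamino group, would stay close to compound 3 and compound 4 or return toward compound 1. They also leave open how amino would behave with pyridin-2-yl in place of 4-fluorophenyl, the change seen in compound 2.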